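The Same Change Made Twice, Seen Only Through Limits

A few compounds are considered here, and "the series" means these few. Any claim that something is new, unique, unknown or untested is made for them only; others in the source may bear on it.

All three measured compounds were tested in a functional assay on the whole organism for antagonist activity, with Mus musculus as the target, in the maximal electroshock model; a lower number here means that less compound is needed, a higher number that more compound is needed for the effect. Compound 1, `Cn1c(-c2cccs2)nnc1[S+](C)[O-]`, gives in this assay > 200 mg/kg, which is a limit of the assay and not a number. Compound 2, `Cn1c(-c2cccs2)nnc1S(C)(=O)=O`, differs from it by a group of 4 heavy atoms (1 carbon, 2 oxygen, 1 sulfur; no ring) in place of a group of 3 heavy atoms (1 carbon, 1 oxygen, 1 sulfur; no ring), on an aromatic carbon. In this assay compound 2 gives > 200 mg/kg, again a limit. The step that the two limits leave unreadable from compound 1 to compound 2 therefore has no readable size. Compound 3, `Cn1c(-c2ccccc2F)nnc1[S+](C)[O-]`, carries a different core; how its core differs from that of compound 1 is not broken down here. In this assay compound 3 gives > 200 mg/kg, also a limit. The whole picture so far is the limit of > 200 mg/kg in this assay, at which 3 of the 3 values shown sit. Compound 4, `Cn1c(-c2ccccc2F)nnc1S(C)(=O)=O`, is not yet measured and differs from compound 3 by a group of 4 heavy atoms (1 carbon, 2 oxygen, 1 sulfur; no ring) in place of a group of 3 heavy atoms (1 carbon, 1 oxygen, 1 sulfur; no ring), on an aromatic carbon. This is the same kind of change as from compound 1 to compound 2, made on the other core. The expected step that the limit leaves unreadable from compound 3 to compound 4 is estimated on the footing of the unread step that the two limits leave unreadable from compound 1 to compound 2 alone. Compound 4 is expected to give about 250 mg/kg, most likely once more as a limit, within an estimated range from 100 mg/kg to 600 mg/kg.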

Compound 4, dose for half-maximal effect: > 100 mg/kg
Compound 4: only a limit was reported; the forecaster's own chance of this, stated with the estimate: 85%; the middle value is on the limit's open side.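

In this assay compound 4 gives > 100 mg/kg, which is a limit and not a number. Among the compounds shown here, compound 3 also stands only at a limit, so no step from compound 3 to compound 4 can be read. The compounds shown leave open how much of each is needed for the effect, and whether placing methylsulfonyl on either core changes that amount.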